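The source may report more compounds than this note shows. Statements on the series, on what has been measured and on what is new or still open speak of the compounds shown alone.

Measured in an ADME assay on HeLa cells (Homo sapiens) for cytotoxicity, read by XTT assay, with a stated time of 3 days; a higher number here means that more compound is tolerated, a lower number that less compound is tolerated:
Compound 1 `C1=C(/C=C/c2ccccn2)COc2ccccc21`: > 50000 nM
Compound 2 `Clc1ccc2c(c1)C=C(/C=C/c1ccccn1)CO2`: > 50000 nM

Compound 1 has no exact number on this scale, only the limit > 50000 nM. Compound 2 likewise gives only a limit, > 50000 nM. Compound 3 `C1=C(/C=C/c2cccnc2)COc2ccccc21` has the same atoms as compound 1, joined differently: pyridin-3-yl in place of pyridin-2-yl on a double-bonded chain carbon bound to a double-bonded chain carbon. Going by the values given here, the one measured step, a step that the two limits leave unreadable from compound 1 to compound 2, is a chloro in place of hydrogen on an aromatic carbon, so it does not touch this exchange and gives no size. Both measured values stand at one limit: the limit of > 50000 nM in this assay, at which 2 of the 2 values shown sit. With compound 1 showing the limit > 50000 nM, no step beyond the scatter is expected in this assay, and no direction can be named. Compound 3 is estimated at 50000 nM, with an expected range of 15000 nM to 100000 nM. This estimate means an expected a number no higher from compound 1 to compound 3 (the limit leaves the size open).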

Compound 3, half-maximal cytotoxic concentration: 75000 nM
Estimate against measurement, compound 3: 1.5-fold (0.18 log units) below; measured number inside the range.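

Compound 3 adds no readable step in this assay: compound 1 has only a limit there, so pyridin-3-yl in place of pyridin-2-yl gets no size. The compounds shown leave open whether this exchange changes the tolerated concentration at all, and in which direction.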